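Compound 3 to Compound 4: A Hydroxypropyl Tail

The source may hold more compounds than are shown below. What is called first, only, known or untested is meant among the compounds shown, and "the series" means these compounds.

Of the compounds shown here, three sharing one core have been measured in a physicochemical assay for lipophilicity; on this read-out higher numbers stand for higher lipophilicity and lower numbers for lower lipophilicity. Compound 1 `O=C(NC1(C(=O)NO)CCCCC1)c1ccc(C#Cc2ccccc2)cc1` gives > 3, which is a limit of the assay rather than a number. Compound 2 `O=C(NC1(C(=O)NO)CCN(Cc2ccccc2)CC1)c1ccc(C#Cc2ccccc2)cc1` likewise gives > 3, again a limit. Among the measured compounds shown here, compound 3 `NC(=O)C[C@H](NC(=O)c1ccc(C#Cc2ccccc2)cc1)C(=O)NO` gives 1, the only actual number among the three. The remaining two values are the limit of > 3 in this assay, at which 2 of the 3 values shown sit. For the measured compounds named here, no step between two measured compounds is available, so nothing measured shows how a change of this kind moves the read-out. Compound 4 `O=C(C[C@H](NC(=O)c1ccc(C#Cc2ccccc2)cc1)C(=O)NO)NCCCO` differs from compound 3 by 3-hydroxypropyl in place of hydrogen on an amide-type nitrogen. Only a small upward step is expected, a number 0.30 log units higher from compound 3 to compound 4 (within the scatter), possibly within the usual scatter. Compound 4 is therefore estimated at about 1.3, between 0.7 and 1.9.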

Compound 4, distribution coefficient: 2
Estimate against measurement, compound 4: 0.70 log units below, outside the stated range (above it).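

In this assay, the amide-type nitrogen of compound 3 proves to be a place where a change moves the reading: 3-hydroxypropyl in place of hydrogen gives a number 1.00 log units higher from compound 3 to compound 4 (beyond the scatter). Among the compounds shown here, this is the first step in the set between two measured compounds, so it is the first direct view of how a single change acts on this read-out. Compound 4 still gives a number rather than a limit: the limit of > 3 in this assay, at which 2 of the 4 values shown sit.

From the compounds shown here alone, what a plain propyl group, a longer chain, or a chain bearing an amine or a carboxylic acid would do on this nitrogen remains open. Going by these compounds, whether the same step would hold on a different compound also remains open.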